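The compounds below may be only part of what the source reports. "The series", "measured", "known", "first", "only" and "open" are said of these compounds alone.

Three compounds built on one shared core were examined in a functional assay on A549 cells (Homo sapiens) for antiproliferative activity, read by MTT assay, with a stated time of 72 h; on this read-out lower numbers stand for stronger inhibition and higher numbers for weaker inhibition. Compound 1 `C/C=C\C(=O)Nc1cc(Nc2nccc(-c3cn(C)c4ccccc34)n2)c(OC)cc1N(C)CCN(C)C` gave 660 nM in this assay. Compound 2 `CC/C=C\C(=O)Nc1cc(Nc2nccc(-c3cn(C)c4ccccc34)n2)c(OC)cc1N(C)CCN(C)C` gave 1530 nM, and compound 3 `CCC/C=C\C(=O)Nc1cc(Nc2nccc(-c3cn(C)c4ccccc34)n2)c(OC)cc1N(C)CCN(C)C` gave 808 nM. Among these three numbers compound 2 stands highest. The step nearest to it is a 1.9-fold lower number from compound 2 to compound 3 (0.28 log units; within the scatter), and the step furthest from it is a 2.3-fold higher number from compound 1 to compound 2 (0.37 log units; beyond the scatter). For completeness, a 1.2-fold higher number from compound 1 to compound 3 (0.09 log units; within the scatter) is also recorded. Every one of these three steps alters the saturated chain attached to the double-bonded chain carbon on the amide side of the molecule; none of them touches the fused ring system.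

Compound 4 `CC/C=C\C(=O)Nc1cc(Nc2nccc(-c3cn(C)c4ccc(F)cc34)n2)c(OC)cc1N(C)CCN(C)C` differs from compound 2 by fluoro in place of hydrogen on an aromatic carbon. Among the compounds with values here, no measured step in this set bears on a change at that position, so there is nothing here from which a shift in either direction can be read. The expected step is therefore a 1.0-fold lower number from compound 2 to compound 4 (0.01 log units; within the scatter), that is, none beyond the scatter of this assay. On that basis compound 4 is estimated at 1500 nM in this assay, with a range that is expected to run from 500 nM to 4500 nM.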

Compound 4, half-maximal inhibitory concentration: 3600 nM
Compound 4: the middle estimate sits 2.4-fold (0.38 log units) below what was measured; low and high end bracket the measured number.
By their numbers in this assay, from the lowest: compounds 1, 3 and 2 (each within the scatter of the next, the first and the last beyond it); then compound 4.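

In this assay, fluoro in place of hydrogen on an aromatic carbon gave a 2.4-fold higher number from compound 2 to compound 4 (0.37 log units; beyond the scatter), a modest step beyond the scatter and towards weaker inhibition. The earlier steps shown here all altered the saturated chain on the amide side and left the fused ring system untouched, so they could say nothing about this position; this result shows that, with the chain of compound 2 in place, the read-out responds to a change at this aromatic carbon, even one as small as a single fluorine atom replacing hydrogen. Nothing available here accounts for the shift.

The compounds shown leave open whether fluoro has a similar effect when paired with the shorter or longer chains of compound 1 and compound 3, since the result rests on a single pair of compounds. They also leave open whether the weaker inhibition is particular to fluoro or would also appear with chloro, methoxy or an amine on the same aromatic carbon, and whether fluoro on another carbon of that ring would give a similar result.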